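This account rests on a few compounds, and the source may have more. Where it says the series, first, only, none or still open, it means among the compounds named here.

Measured in a functional assay on KB cells (Homo sapiens) for inhibition, read by MTT assay, with a stated time of 24 h, tested at 0.1 ug/mL; a lower number here means less inhibition of growth, a higher number more inhibition of growth at the concentration tested:
- compound 1 `O=C(CCCCC(S)CCS)Nc1ccccc1`: 9.49%
- compound 2 `O=C(CCCCC(S)CCS)Nc1cccc(Cl)c1`: "not active" (no number reported)
- compound 3 `O=C(CCCCC(S)CCS)Nc1cccc(C(F)(F)F)c1`: 8.41%

Compound 3, at 8.41%, lies within the scatter of compound 1, at 9.49%. Growth inhibition at this concentration is therefore slight for both, and compound 2 gives no number to compare.

The next compound is compound 4 `Cc1cccc(NC(=O)CCCCC(S)CCS)c1`, which carries methyl in place of trifluoromethyl on an aromatic carbon. Among the measured compounds shown here, one measured step bears on this change, trifluoromethyl in place of hydrogen on an aromatic carbon, and it is small: a number 1.1 percentage points lower from compound 1 to compound 3 (within the scatter). Nothing has yet been measured with methyl on the ring. With hydrogen and trifluoromethyl giving numbers within the scatter of each other, no step beyond the scatter is expected in this assay. The expected step is a number 0.6 percentage points higher from compound 3 to compound 4 (within the scatter), which would stay within the scatter. For the measured compounds named here, a report without a number, like the one for compound 2, also remains possible. For compound 4 the estimated value is 9%, with an expected range of 2% to 18%.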

Compound 4, percent growth inhibition at one concentration: 5.75%
Beside the measured number, compound 4's estimate is 3.3 percentage points above it; measured number inside the range.
By their numbers in this assay, from the lowest: compounds 4, 3 and 1 (each within the scatter of the next).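

In this assay the change to methyl from trifluoromethyl gives a number 2.7 percentage points lower from compound 3 to compound 4 (within the scatter) and the change to methyl from hydrogen gives a number 3.7 percentage points lower from compound 1 to compound 4 (within the scatter) on the same aromatic carbon. Methyl thus joins hydrogen and trifluoromethyl as a third group at this position that the read-out cannot separate, so exchanging these three shows no effect on growth inhibition at the single concentration tested. No measurement at hand offers an explanation for how close these numbers lie.

As far as these compounds go, whether an amine or a carboxylic acid on this aromatic carbon would move the number beyond the scatter stays open. Also open, from the compounds shown here alone, are how compound 2, reported as not active without a number, compares with the others, and whether a longer chain in place of the shared chain would change the picture.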